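Furan to phenyl on the acrylamide chain

The source may hold more compounds than are shown below. What is called first, only, known or untested is meant among the compounds shown, and "the series" means these compounds.

Working notes on the series. Compound 1 `N#C/C(=C\c1ccc[nH]1)C(=O)NCc1ccc(Cl)c(Cl)c1` and compound 2 `N#C/C(=C\c1ccco1)C(=O)NCc1ccc(Cl)c(Cl)c1` share a core and differ only in the aromatic group on the double-bonded chain carbon. In a functional assay on SMA cells (Homo sapiens) for inhibition, read by MTT assay, with a stated time of 72 h (on this read-out higher numbers stand for weaker inhibition of growth and lower numbers for stronger inhibition of growth), compound 1 gives > 50000 nM, which is a limit of the assay and not a number. Compound 2 gives 38000 nM in this assay, the only plain number shown. The other value shown, that of compound 1, is a limit (the limit of > 50000 nM in this assay, at which 1 of the 2 values shown sits). Going by the values given here, the step of an at least 1.3-fold lower number from compound 1 to compound 2 (0.11 log units; that floor lies within the scatter) is the only measured step, and its floor lies within the scatter. Compound 3 `N#C/C(=C\c1ccccc1)C(=O)NCc1ccc(Cl)c(Cl)c1` carries the change (phenyl in place of furan-2-yl on a double-bonded chain carbon bound to a double-bonded chain carbon). Among the compounds with values here, no measured step touches a phenyl group, so the expectation rests on compound 2 alone and on the fact that the one exchange measured on this position changed little. The step of a 1.1-fold lower number from compound 2 to compound 3 (0.04 log units; within the scatter) is therefore expected to be no more than within the scatter, in no clear direction. Compound 3 is estimated at 35000 nM in this assay, within a range from 10000 nM to 120000 nM.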

Compound 3, concentration for 50% growth inhibition: 43000 nM
Compound 3: middle estimate off by 1.2-fold (0.09 log units), on the low side, and the stated range covers the measured number.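

In this assay, the step of a 1.1-fold higher number from compound 2 to compound 3 (0.05 log units; within the scatter) shows that phenyl can stand in place of furan-2-yl at this position, losing the hetero atom and the hydrogen-bond acceptor, with the two values still within the scatter of each other. The step of an at least 1.1-fold lower number from compound 1 to compound 3 (0.06 log units; that floor lies within the scatter) gives only a floor that lies within the scatter, so it sets no order between these two compounds. Compound 1 is a limit of the assay and not a number: the limit of > 50000 nM in this assay, at which 1 of the 3 values shown sits.

The compounds shown leave open whether a phenyl carrying a hydroxyl or an amine on its ring would move the number beyond the scatter. Also open, as far as these compounds go, is whether any change elsewhere on the shared core, such as a carboxylic acid in place of the nitrile, would do so.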